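A few compounds are considered here, and "the series" means these few. Any claim that something is new, unique, unknown or untested is made for them only; others in the source may bear on it.

Measured compounds:
compound 1, `COc1cc(C2=NN(C(C)=O)C(c3ccccc3C(F)(F)F)O2)cc(OC)c1OC`, -11%
compound 2, `COc1cc(C(=O)N/N=C/c2ccc(C(F)(F)F)cc2)cc(OC)c1OC`, 59.9%
compound 3, `COc1cc(C(=O)N/N=C/c2c(Cl)cccc2Cl)cc(OC)c1OC`, 43%

Of the compounds shown here, three have been measured in a functional assay on PC-3 cells (Homo sapiens) for antiproliferative activity, read by MTT assay, tested at 1 uM; on this read-out lower numbers stand for a weaker effect and higher numbers for a stronger effect at the one concentration tested. Compound 1 gives -11%, the lowest of the three numbers. Compound 3 stands above it by a gap beyond the scatter, and compound 2 stands further above it, also beyond the scatter. Compounds 2 and 3 do not share the core of compound 1, so their numbers only show where compound 1 stands, not how its own core behaves when changed.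

Compound 4, `COc1cc(C2=NN(C(C)=O)C(c3cccc(C(F)(F)F)c3)O2)cc(OC)c1OC`, has not yet been measured in this assay. It differs from compound 1 in one place: 3-(trifluoromethyl)phenyl in place of 2-(trifluoromethyl)phenyl on a saturated ring carbon. Among the measured compounds shown here, no measured pair shows what this kind of change does, so the size of the step is open. A small step is expected, most likely within the scatter of repeated measurements, with any movement more likely upward than downward. Compound 4 is therefore estimated at 5%, in the range -20% to 35%, which means an expected step of a number 16 percentage points higher from compound 1 to compound 4 (beyond the scatter).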

Compound 4, a percentage reported as inhibition, at one concentration (the size of the read-out at that concentration, not a potency): 30.1%
Beside the measured number, compound 4's estimate is 25.1 percentage points below it; the measured number falls inside the stated range.
By their numbers in this assay, from the lowest: compound 1; then compound 4; then compound 3; then compound 2.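

Replacing 2-(trifluoromethyl)phenyl with 3-(trifluoromethyl)phenyl on the saturated ring carbon of the shared core gives a large change in this assay, a number 41.1 percentage points higher from compound 1 to compound 4 (beyond the scatter), although the group that leaves and the group that enters hold the same atoms. Among the compounds shown here, this is the first measured step on this core, and it shows that the read-out at this position depends on where the trifluoromethyl group sits on the phenyl ring, even with the composition unchanged. Nothing at hand explains why this rearrangement has such an effect.

The compounds shown leave open whether the trifluoromethyl group is needed at all, since a plain phenyl, a chlorophenyl or a methoxyphenyl on this carbon would test that. They also leave open how the result would change if a longer chain, such as propanoyl, replaced the acetyl group.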